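This account rests on a few compounds, and the source may have more. Where it says the series, first, only, none or still open, it means among the compounds named here.

Compound 2 (`Cn1cccc1-c1nc2cc(NC(=O)CCCl)ccc2[nH]1`) gives > 50000 nM in a functional assay on HepG2 cells (Homo sapiens) for cytotoxicity, read by MTT assay, with a stated time of 72 h (on this read-out lower numbers stand for stronger inhibition and higher numbers for weaker inhibition), which is a limit of the assay and not a number. Compound 3 (`CCN1CCN(CC(=O)Nc2ccc3[nH]c(-c4cccn4C)nc3c2)CC1`) gives > 50000 nM, also a limit. Compound 1 (`CCN1CCN(CCC(=O)Nc2ccc3[nH]c(-c4ccc(Br)cc4)nc3c2)CC1`) gives a true number, 27400 nM. Compound 4 (`Cn1cccc1-c1nc2cc(NC(=O)CCl)ccc2[nH]1`) differs from compound 2 in one place: chloro in place of chloromethyl on a saturated chain carbon bound to a carbonyl carbon, with chloro in place of chloromethyl on a saturated chain carbon bound to a carbonyl carbon. Going by the values given here, the only measured step that bears on this change is a step that the two limits leave unreadable from compound 2 to compound 3, so it offers no size to borrow. The data stop at the limit of > 50000 nM in this assay, at which 2 of the 3 values shown sit. A modest move toward stronger inhibition is expected, estimated as an at least 1.2-fold lower number from compound 2 to compound 4 (0.09 log units; that floor lies within the scatter). For compound 4 the expected value is 40000 nM, with an estimated range of 15000 nM to 100000 nM.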

Compound 4, half-maximal inhibitory concentration: 1800 nM
The estimate for compound 4 lay 22-fold (1.35 log units) above the measured number; the whole stated range lies above it.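

Cutting 2-chloroethyl down to chloromethyl, a change of one carbon, gives the first readable effect at this place in this assay: an at least 27-fold lower number from compound 2 to compound 4 (1.44 log units; beyond the scatter). Chloro in place of 4-ethylpiperazin-1-yl on the same chain carbon gives an at least 27-fold lower number from compound 3 to compound 4 (1.44 log units; beyond the scatter). Both sizes are minimums, and the step between the two weak compounds cannot be read, since compound 2 and compound 3 each rest on a limit and not a number: the limit of > 50000 nM in this assay, at which 2 of the 4 values shown sit.

Going by these compounds, what a bromomethyl or aminomethyl group would give at this place remains open. So does whether chloromethyl would give a similar gain on the core of compound 1.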